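Methyl to Isopropyl on the Ester Oxygen: an Estimate

The source may report more compounds than this note shows. Statements on the series, on what has been measured and on what is new or still open speak of the compounds shown alone.

Measured so far in a functional assay (cardiac atrium) for agonist activity, with Cavia porcellus as the target; on this read-out higher numbers stand for an effect only at larger amounts of compound and lower numbers for an effect already at smaller amounts:
- compound 1 `CC1=NC(C)=C([N+](=O)[O-])C(c2ccccn2)/C1=C(\O)OC1CCCC1` gives 19800 nM
- compound 2 `CO/C(O)=C1\C(C)=NC(C)=C([N+](=O)[O-])C1c1ccncc1` gives 48500 nM
- compound 3 `CC1=NC(C)=C([N+](=O)[O-])C(c2cccnc2)/C1=C(\O)OC1CCCCC1` gives 2760 nM

Among these three, compound 2 stands at the highest number in this assay. Its nearest neighbour is compound 1, and the gap between them lies beyond the scatter; the gap to compound 3 is far wider and also beyond the scatter. Compound 2 is thus the weakest of the three on this read-out.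

Compound 4 `CC1=NC(C)=C([N+](=O)[O-])C(c2ccncc2)/C1=C(\O)OC(C)C` has not been measured. It differs from compound 2 in one place: isopropyl in place of methyl on an oxygen on an unsaturated carbon. Compounds 1 and 3 carry larger groups on that oxygen and show lower numbers than compound 2, but each of them also differs from compound 2 elsewhere, so the two cannot be read as a step. For compound 4 a move to a lower number is expected, of modest size, as a 3.2-fold lower number from compound 2 to compound 4 (0.51 log units; beyond the scatter). The value of compound 4 in this assay is estimated at 15000 nM, with a range from 5000 nM to 50000 nM.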

Compound 4, half-maximal effective concentration: 8050 nM
Compound 4: middle estimate off by 1.9-fold (0.27 log units), on the high side, within the range that was stated.
By their numbers in this assay, from the lowest: compound 3; then compound 4; then compound 1; then compound 2.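

In this assay the change from methyl to isopropyl on an oxygen on an unsaturated carbon can now be read as a single step, a 6.0-fold lower number from compound 2 to compound 4 (0.78 log units; beyond the scatter), and this step lies beyond the scatter. Compounds 1 and 3 also carry larger groups on that oxygen, but each differs from compound 2 elsewhere as well, so they could not separate the group on the oxygen from those other differences. This pair shows that methoxy to isopropoxy alone, with the rest of the structure unchanged, moves the number lower, and no measurement at hand bears on why it does so.

Two points are all that the compounds shown give for this change, so it remains open whether a tert-butyl group, a benzyl group or a longer chain on this oxygen would take the number lower still or bring it back up. From the compounds shown here alone, it is equally open whether the same change would give a step of similar size on the cores of compound 1 and compound 3, which differ from compound 2 in another place as well.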